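The compounds below may be only part of what the source reports. "The series", "measured", "known", "first", "only" and "open" are said of these compounds alone.

Working notes on the series.

Compound 1 `Cn1c(-c2ccc(F)cc2)nc2c(NC3CCCC3)ncnc21` and compound 2 `Cc1cccc(-c2nc3c(NC4CCCC4)ncnc3n2C)c1` share one core and differ only in the aryl group on it. In a functional assay (strain BALB/C) for antagonist activity at adenosine receptor A1 (Mus musculus), with a stated time of 1 h, tested at 1 uM (a higher number here means a weaker inhibitor, a lower number a stronger inhibitor), compound 1 gives 43 nM. Compound 2 in this assay gives 33 nM. The step from one to the other, a 1.3-fold lower number from compound 1 to compound 2 (0.11 log units; within the scatter), is a swap of the whole aryl substituent pattern without a change beyond the scatter. Compound 2 therefore stands on the lower of the two numbers seen so far, with compound 1 within the scatter of it, so no order between the two can be claimed.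

Compound 3 `Cn1c(-c2ccccc2)nc2c(NC3CCCC3)ncnc21` is the next point: hydrogen in place of methyl on an aromatic carbon, the group sitting on a six-membered aromatic ring of carbon only, meta to a large group; read one bond further out, the change is 3-methylphenyl to phenyl. Going by the values given here, the only measured step that bears on it is a 1.3-fold lower number from compound 1 to compound 2 (0.11 log units; within the scatter), which shows that a change of the ring substituent left this assay unmoved. Among the compounds with values here, no step removes a substituent outright, so the direction is open. A step within the scatter, or a small rise, is expected: a 1.4-fold higher number from compound 2 to compound 3 (0.13 log units; within the scatter). Compound 3 is thus estimated at 45 nM in this assay, within 18 nM to 115 nM.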

Compound 3, antagonist equilibrium constant: 17 nM
Compound 3: middle estimate off by 2.6-fold (0.42 log units), on the high side; the measured number lies below the stated range.
By their numbers in this assay, from the lowest: compounds 3, 2 and 1 (each within the scatter of the next, the first and the last beyond it).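

Taking the ring substituent away altogether is now covered, and the two readings of it in this assay differ in size: a 1.9-fold lower number from compound 2 to compound 3 (0.29 log units; within the scatter), hydrogen in place of methyl on an aromatic carbon, whereas a 2.5-fold lower number from compound 1 to compound 3 (0.40 log units; beyond the scatter), where the fluoro group leaves the ring. Going by these compounds alone, the earlier pair showed only that one substituted aryl group could stand in for another without a change beyond the scatter; the plain phenyl of compound 3 now gives the first separation, modest in size and held only against the fluoro compound, since compound 3 and compound 2 cannot be ordered. Neither methyl nor fluoro is therefore needed on this ring to hold the number in this range, and nothing at hand bears on why the fluoro step reaches beyond the scatter.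

From the compounds shown here alone, whether this trend holds for other groups on the ring, such as methoxy, an amine, a carboxylic acid or a longer chain, remains open. Also open, going by these compounds, is whether the same step would read alike with the rest of the shared core changed.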